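Replacing 3-hydroxyphenyl with 4-fluorophenyl on a shared core

The compounds below may be only part of what the source reports. "The series", "measured", "known", "first", "only" and "open" are said of these compounds alone.

In a functional assay on A549 cells (Homo sapiens) for antiproliferative activity, read by MTT assay, with a stated time of 72 h (a lower number here means a stronger inhibitor, a higher number a weaker inhibitor), compound 1 `Cc1nc(C)c(/C=C/C(=O)/C=C/c2cccc(O)c2)nc1C` gives 4300 nM. Its only measured relative, compound 2 `COc1cccc(/C=C/C(=O)/C=C/c2nc(C)c(C)nc2C)c1`, gives 3300 nM, and the two cannot be told apart.

Compound 3 `Cc1nc(C)c(/C=C/C(=O)/C=C/c2ccc(F)cc2)nc1C` has not yet been measured. It keeps the core of compound 1 and changes one group: 4-fluorophenyl in place of 3-hydroxyphenyl on a double-bonded chain carbon bound to a double-bonded chain carbon. This is 4-fluorophenyl in place of 3-hydroxyphenyl on a double-bonded chain carbon bound to a double-bonded chain carbon.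

Among the compounds with values here, only one measured step bears on this change, and only in part. Putting methyl in place of hydrogen on an oxygen on an aromatic ring gives a 1.3-fold lower number from compound 1 to compound 2 (0.11 log units; within the scatter), which lies within the scatter. That step touches the same group, since compound 2 keeps the oxygen and loses only its hydrogen. Within the data shown here, no measured compound shows what removing the oxygen or adding fluorine does, so the evidence is thin.

No change beyond the scatter is therefore expected, and the estimate is a 1.1-fold lower number from compound 1 to compound 3 (0.03 log units; within the scatter). For compound 3 the expected value is 4000 nM, with an estimated range from 1500 nM to 10000 nM.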

Compound 3, half-maximal inhibitory concentration: 5900 nM
Beside the measured number, compound 3's estimate is 1.5-fold (0.17 log units) below it; the measured number falls inside the stated range.
By their numbers in this assay, from the lowest: compounds 2, 1 and 3 (each within the scatter of the next).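

In this assay, the step from the hydroxyl-bearing ring to the fluorine-bearing ring is a 1.4-fold higher number from compound 1 to compound 3 (0.14 log units; within the scatter), so the two compounds cannot be told apart. Compound 2 kept the oxygen and capped its hydrogen, whereas compound 3 removes the oxygen altogether, and the group that enters has 0 hydrogen-bond donors and 0 hydrogen-bond acceptors, where 3-hydroxyphenyl has 1 of each. For these compounds, then, the hydroxyl group of compound 1 is not needed to keep the number in the same range, and this position accepts a quite different substituted phenyl ring without a change beyond the scatter. Nothing shown here offers a measured explanation for why the numbers stay so close.

Going by these compounds, compound 3 alters both the substituent and where it sits on the ring, so the effect of each alone stays unknown, and 4-hydroxyphenyl, 3-fluorophenyl or plain phenyl would be needed to separate them. On these data alone, it also remains open whether the number would stay in this range with an amine or a carboxylic acid on the ring, or whether any group at this position can move it beyond the scatter.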